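From 4-methylphenyl to phenyl on the sulfonyl group

The source may report more compounds than this note shows. Statements on the series, on what has been measured and on what is new or still open speak of the compounds shown alone.

In a functional assay on thoracic aorta (Rattus norvegicus, strain Wistar), with a stated time of 15 min (a higher number here means that more compound is needed for the effect, a lower number that less compound is needed), compound 1 (`Cc1ccc(S(=O)(=O)N(C)C(=O)NC(C)c2cc(Br)ccc2OCc2ccccc2)cc1`) gives 67100 nM and stands second highest of the three measured numbers. Compound 2 (`CCOc1ccc(Br)cc1C(C)NC(=O)N(C)S(=O)(=O)c1ccc(C)cc1`) gives 28600 nM and lies lower, while compound 3 (`Cc1ccc(S(=O)(=O)N(C)C(=O)NC(C)c2cc(C)ccc2OCc2ccccc2)cc1`) gives 181000 nM and lies higher. Among the compounds with values here, the unmeasured compound 4 (`CC(NC(=O)N(C)S(=O)(=O)c1ccccc1)c1cc(Br)ccc1OCc1ccccc1`) departs from compound 1 by hydrogen in place of methyl on an aromatic carbon as its single change, hydrogen in place of methyl on an aromatic carbon, which turns (4-methylphenyl)sulfonyl into phenylsulfonyl. Within the data shown here, no measured step touches that group, so the evidence is only indirect. Methyl in place of phenyl on a saturated chain carbon gave a 2.3-fold lower number from compound 1 to compound 2 (0.37 log units; beyond the scatter) and methyl in place of bromo on an aromatic carbon gave a 2.7-fold higher number from compound 1 to compound 3 (0.43 log units; beyond the scatter) and both of these are modest. A step no larger than those is therefore expected, with no firm direction and quite possibly nothing beyond the scatter. The estimate amounts to a 1.0-fold higher number from compound 1 to compound 4 (0.02 log units; within the scatter) as the expected step. Compound 4 is expected at 70000 nM with an estimated range from 28000 nM to 170000 nM in this assay once it is measured.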

Compound 4, half-maximal effective concentration: 60300 nM
Beside the measured number, compound 4's estimate is 1.2-fold (0.06 log units) above it; the range from low to high includes it.
By their numbers in this assay, from the lowest: compound 2; then compounds 4 and 1 (each within the scatter of the next); then compound 3.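

Taking the methyl off the 4-methylphenyl group, para to a large group, gives a 1.1-fold lower number from compound 1 to compound 4 (0.05 log units; within the scatter) in this assay, so this is the one change shown at the sulfonyl end of the molecule and it leaves the number where it was. The earlier steps, a 2.3-fold lower number from compound 1 to compound 2 (0.37 log units; beyond the scatter) and a 2.7-fold higher number from compound 1 to compound 3 (0.43 log units; beyond the scatter), both lay beyond the scatter, whereas this one does not, so among the compounds shown the methyl on this ring can be lost without a readable change in this assay. Nothing available explains why the number holds.

The compounds shown compare only methyl and hydrogen at this position, so it remains open whether a methoxy group, a chlorine or an amine there would shift the number. As far as these compounds go, it also remains open whether the same change would read alike on compound 2 or compound 3.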